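A Trifluoromethyl Swap on the Amide Nitrogen

The compounds below may be only part of what the source reports. "The series", "measured", "known", "first", "only" and "open" are said of these compounds alone.

In a functional assay on BXPC-3 cells (Homo sapiens) for inhibition, read by MTT assay (on this read-out lower numbers stand for stronger inhibition and higher numbers for weaker inhibition), compound 1 (`COc1ccccc1NC(=O)c1cc2cnc(Nc3ccc(N4CCNCC4)cn3)nc2n1C1CCCC1`) gives 4120 nM and compound 2 (`COc1ccc(NC(=O)c2cc3cnc(Nc4ccc(N5CCNCC5)cn4)nc3n2C2CCCC2)c(OC)c1`) gives 3650 nM so the two stand level within the scatter. Compound 3 (`O=C(Nc1ccccc1C(F)(F)F)c1cc2cnc(Nc3ccc(N4CCNCC4)cn3)nc2n1C1CCCC1`) carries 2-(trifluoromethyl)phenyl in place of 2,4-dimethoxyphenyl on an amide-type nitrogen. Among the measured compounds shown here, the only measured step bearing on this is a 1.1-fold lower number from compound 1 to compound 2 (0.05 log units; within the scatter) for methoxy in place of hydrogen on an aromatic carbon, and no measured step covers trifluoromethyl. In this assay the estimated step is a 1.0-fold higher number from compound 2 to compound 3 (0.02 log units; within the scatter) so no change beyond the scatter is expected. Compound 3 is estimated at 3800 nM with an expected range of 1500 nM to 9000 nM given so few measurements.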

Compound 3, half-maximal inhibitory concentration: 8040 nM
The estimate for compound 3 lay 2.1-fold (0.33 log units) below the measured number, and the stated range covers the measured number.
By their numbers in this assay, from the lowest: compounds 2, 1 and 3 (each within the scatter of the next, the first and the last beyond it).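

At this amide-type nitrogen, the aryl group can move the number beyond the scatter, which the methoxy step had not done: in this assay, 2-(trifluoromethyl)phenyl in place of 2,4-dimethoxyphenyl gives a 2.2-fold higher number from compound 2 to compound 3 (0.34 log units; beyond the scatter). Trifluoromethyl in place of methoxy gives a 2.0-fold higher number from compound 1 to compound 3 (0.29 log units; within the scatter), so the shift is modest and the one-group swap stays within the scatter. Nothing measured here explains the step. Still open, going by these compounds, is how a nitrile or a carboxylic acid in place of the trifluoromethyl would read in this assay.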